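Replacing the acetyl group on the shared core

The source may hold more compounds than are shown below. What is called first, only, known or untested is meant among the compounds shown, and "the series" means these compounds.

Compound 1 `CC(=O)N1N=C(c2ccc(N3CCN(C)CC3)cc2)CC1c1ccc(N(C)C)cc1` gives -1.9% in a functional assay on NCI-H1975 cells (Homo sapiens) for inhibition, read by sulforhodamine B assay, tested at 10 uM; a higher number here means more inhibition at the concentration tested (going by the name of the read-out), a lower number less inhibition. Compound 2 `CN1CCN(c2ccc(C3=NN(C(=O)c4ccc(C(F)(F)F)cc4)C(c4ccc(N(C)C)cc4)C3)cc2)CC1` gives 93.2%, and compound 3 `CC(=O)N1N=C(c2ccc(-n3cncn3)cc2)CC1c1ccc(N(C)C)cc1` gives -0.3%. Among the compounds with values here, the step of a number 95.1 percentage points higher from compound 1 to compound 2 (beyond the scatter) is the only change at the carbonyl carbon measured so far, while the step of a number 1.6 percentage points higher from compound 1 to compound 3 (within the scatter) exchanged the substituent on an aromatic carbon instead. Compound 3 therefore stands second highest of the three numbers, within the scatter of compound 1 and far below compound 2, beyond the scatter.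

Compound 4 `CN(C)c1ccc(C2CC(c3ccc(-n4cncn4)cc3)=NN2C(=O)/C=C/c2ccccc2)cc1` differs from compound 3 as follows: 2-phenylethenyl in place of methyl on a carbonyl carbon. The precedent that bears on this is a number 95.1 percentage points higher from compound 1 to compound 2 (beyond the scatter), where a larger carbonyl substituent in place of methyl lifted the number far beyond the scatter; a number 1.6 percentage points higher from compound 1 to compound 3 (within the scatter) does not concern the carbonyl carbon. The entering 2-phenylethenyl group is not the same as the group in compound 2, so the expected step of a number 60.3 percentage points higher from compound 3 to compound 4 (beyond the scatter) is upward with wide uncertainty. Compound 4 is estimated at 60%, within 15% to 95%.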

Compound 4, a percentage reported as inhibition, at one concentration (the size of the read-out at that concentration, not a potency): -2.3%
Compound 4: the middle estimate sits 62.3 percentage points above what was measured, and the stated range ends above it.
By their numbers in this assay, from the lowest: compounds 4, 1 and 3 (each within the scatter of the next); then compound 2.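

The step of a number 2 percentage points lower from compound 3 to compound 4 (within the scatter) in this assay shows that a larger carbonyl substituent bearing an aromatic ring does not in itself raise the number at this carbon. Entry of 2-phenylethenyl in place of methyl leaves the reading where it was, and compound 2 stands as the exception to any broader rule, either for or against size at this position. The two steps at this carbon start from compounds with different groups on the aromatic carbon, 4-methylpiperazin-1-yl in one and 1H-1,2,4-triazol-1-yl in the other, and no measurement available here accounts for their different outcomes.

Still open, from the compounds shown here alone, is whether the large rise depends on the entering 4-(trifluoromethyl)phenyl, on the 4-methylpiperazin-1-yl group, or on both together. A plain phenyl or a saturated 2-phenylethyl group on the carbonyl carbon, paired with each of those two aromatic substituents, would help to separate these readings.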